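The source may hold more compounds than are shown below. What is called first, only, known or untested is meant among the compounds shown, and "the series" means these compounds.

Measured so far in a functional assay on K562 cells (Homo sapiens), read by MTT assay, with a stated time of 72 h; on this read-out lower numbers stand for stronger inhibition and higher numbers for weaker inhibition:

- Compound 1 `O=c1[nH]cnc2c1c(-c1ccoc1)cn2[C@@H]1O[C@H](CO)[C@@H](O)[C@H]1O` gives 14500 nM.
- Compound 2 `O=c1[nH]cnc2c1c(-c1cccs1)cn2[C@@H]1O[C@H](CO)[C@@H](O)[C@H]1O` gives only a limit of the assay, > 20000 nM.
- Compound 3 `Nc1nc2c(c(-c3cccs3)cn2[C@@H]2O[C@H](CO)[C@@H](O)[C@H]2O)c(=O)[nH]1` gives 16800 nM.

All three share a sugar-bearing core and differ at two spots. The first is the ring hanging from the core. From compound 2 to compound 1 the change is furan-3-yl in place of thiophen-2-yl on an aromatic carbon, and the result is an at least 1.3-fold lower number from compound 2 to compound 1 (0.13 log units; that floor lies within the scatter). Since compound 2 sits at a limit, the true size of that step is not fixed; it is known only as a floor, and that floor lies within the usual scatter.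

The second spot is on the core itself. From compound 2 to compound 3 the change is amino in place of hydrogen on an aromatic carbon, giving an at least 1.1-fold lower number from compound 2 to compound 3 (0.07 log units; that floor lies within the scatter). Again the step begins at a limit and its floor lies within the scatter, so compound 3 and compound 1 cannot be put in order by these numbers.

Compound 4 `Nc1nc2c(c(-c3ccoc3)cn2[C@@H]2O[C@H](CO)[C@@H](O)[C@H]2O)c(=O)[nH]1` is not yet measured. It is reached from compound 3 by furan-3-yl in place of thiophen-2-yl on an aromatic carbon, the same change as from compound 2 to compound 1, at the same place word for word. The expected step is a 1.4-fold lower number from compound 3 to compound 4 (0.15 log units; within the scatter), resting on the earlier step of an at least 1.3-fold lower number from compound 2 to compound 1 (0.13 log units; that floor lies within the scatter), which is only a floor and is within the scatter. Compound 4 is therefore estimated to give about 12000 nM in this assay, most likely between 5000 nM and 30000 nM.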

Compound 4, half-maximal inhibitory concentration: 12500 nM
Compound 4: the middle estimate sits 1.0-fold (0.02 log units) below what was measured, and the stated range covers the measured number.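

Furan-3-yl in place of thiophen-2-yl on the amino-bearing core gives a 1.3-fold lower number from compound 3 to compound 4 (0.13 log units; within the scatter), and this can now be set beside the same change on the other core: the same change on two cores in this assay, an at least 1.3-fold lower number (0.13 log units; that floor lies within the scatter) from compound 2 to compound 1 and a 1.3-fold lower number (0.13 log units; within the scatter) from compound 3 to compound 4; the limit leaves it open whether they differ. Amino in place of hydrogen, made on the compounds that carry furan-3-yl, gives a 1.2-fold lower number from compound 1 to compound 4 (0.06 log units; within the scatter), and this change too can now be read on two cores: the same change on two cores in this assay, an at least 1.1-fold lower number (0.07 log units; that floor lies within the scatter) from compound 2 to compound 3 and a 1.2-fold lower number (0.06 log units; within the scatter) from compound 1 to compound 4; the limit leaves it open whether they differ. Every one of these steps lies within the scatter or is only a floor, so the four compounds in this assay fit with either change carrying over from one core to the other, but they do not prove that it does, and they show no clear gain from either change.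

The compounds shown leave open whether a different group at these places, such as a phenyl ring or a longer alkyl chain in place of the five-membered ring, or a methyl group or a dimethylamino group in place of the amino group, would give a step beyond the scatter. They also leave open how far the true value of compound 2 lies from the others: the limit of > 20000 nM in this assay, at which 1 of the 4 values shown sits.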